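The compounds below may be only part of what the source reports. "The series", "measured", "known", "first", "only" and "open" are said of these compounds alone.

Three compounds share one core and differ only in the group hung from it. Compound 1 `Nc1cc(N)c2nc(-c3ccccc3)c(Oc3ccc(Cl)c(Cl)c3)nc2c1` carries its side group through an oxygen; in a functional assay on Malme-3M cells (Homo sapiens) for inhibition, read by sulforhodamine B assay, with a stated time of 48 h (on this read-out higher numbers stand for weaker inhibition of growth and lower numbers for stronger inhibition of growth), compound 1 gives 15800 nM. Compound 2 `Nc1cc(N)c2nc(-c3ccccc3)c(NCc3ccc(Cl)c(Cl)c3)nc2c1` carries a 3,4-dichlorophenyl on a saturated chain carbon bound to a ring nitrogen, and in this assay compound 2 gives 3390 nM. Compound 3 `COc1ccc(CNc2nc3cc(N)cc(N)c3nc2-c2ccccc2)cc1OC` gives 5620 nM in this assay. Compound 3 thus sits second highest of the three numbers: compound 1 gives a higher number than compound 3, beyond the scatter, while the values of compound 2 and compound 3 lie within the scatter of each other, as the step of a 1.7-fold higher number from compound 2 to compound 3 (0.22 log units; within the scatter) shows.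

Compound 4 `COc1ccc(CNc2nc3cc(N)cc(N)c3nc2-c2ccccc2)cc1` is not yet measured. It differs from compound 3 by hydrogen in place of methoxy on an aromatic carbon. Within the data shown here, only one measured step touches this part of the molecule: the exchange of the whole 3,4-dichlorophenyl for 3,4-dimethoxyphenyl, which moved the number by a 1.7-fold higher number from compound 2 to compound 3 (0.22 log units; within the scatter), within the scatter. Among the measured compounds shown here, no measured step removes a single methoxy alone. The expected change is therefore a 1.1-fold higher number from compound 3 to compound 4 (0.03 log units; within the scatter), no step beyond the scatter. Compound 4 is estimated at 6000 nM, within a range of 2500 nM to 14000 nM.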

Compound 4, concentration for 50% growth inhibition: 10700 nM
Beside the measured number, compound 4's estimate is 1.8-fold (0.25 log units) below it, and the stated range covers the measured number.
By their numbers in this assay, from the lowest: compounds 2, 3, 4 and 1 (each within the scatter of the next, the first and the last beyond it).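

Among these compounds, this is the first measured step that removes a single methoxy from the aromatic ring: hydrogen in its place on an aromatic carbon gives a 1.9-fold higher number from compound 3 to compound 4 (0.28 log units; within the scatter) in this assay, so this change alone cannot be told from the usual scatter. A difference appears only against the dichloro compound: 4-methoxyphenyl in place of 3,4-dichlorophenyl gives a 3.2-fold higher number from compound 2 to compound 4 (0.50 log units; beyond the scatter) and passes beyond the scatter, though only modestly, while 3,4-dimethoxyphenyl in that same place gave a 1.7-fold higher number from compound 2 to compound 3 (0.22 log units; within the scatter) and stayed within it. The side group can therefore shift the number, but this single methoxy has no effect that can be separated from the scatter.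

On these data alone, whether an amine or a carboxylic acid on this aromatic carbon would move the number remains open. Nothing here gives a reason for these numbers.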